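The source may report more compounds than this note shows. Statements on the series, on what has been measured and on what is new or still open speak of the compounds shown alone.

Measured in a functional assay on KB cells (Homo sapiens) for antiproliferative activity, read by sulforhodamine B assay, with a stated time of 48 h; on this read-out lower numbers stand for stronger inhibition of growth and higher numbers for weaker inhibition of growth:
- compound 1 `COc1ccc(S(=O)(=O)Nc2ccc(CCc3ccc(C(=O)Nc4ccccc4N)cc3)cc2)cc1`: > 10000 nM (a limit of the assay, not a number)
- compound 2 `Nc1ccccc1NC(=O)c1ccc(CCc2ccccc2NS(=O)(=O)c2ccccc2)cc1`: 456 nM

Going by the values given here, compound 2 holds the only actual number so far. Compound 3 `Nc1ccccc1NC(=O)c1ccc(CCc2ccccc2NS(=O)(=O)c2ccc(F)cc2)cc1` differs from it by fluoro in place of hydrogen on an aromatic carbon, para to a large group. Among the compounds with values here, no step between measured compounds is available to size this change. The expected change is a 1.1-fold lower number from compound 2 to compound 3 (0.06 log units; within the scatter), which is no more than the scatter and has no firm direction. The estimate for compound 3 is 400 nM, with an expected range of 150 nM to 1100 nM.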

Compound 3, concentration for 50% growth inhibition: 884 nM
The estimate for compound 3 lay 2.2-fold (0.34 log units) below the measured number; the measured number falls inside the stated range.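

In this assay, going by these compounds alone, fluoro in place of hydrogen on the phenylsulfonyl ring gives a 1.9-fold higher number from compound 2 to compound 3 (0.29 log units; within the scatter) and is the first sized step. This aromatic carbon, para to a large group, therefore accepts a fluoro without a change beyond the scatter. Nothing measured here bears on a cause for this step.

Still open, going by these compounds, is how a group other than fluoro at this place, such as an amine or a carboxylic acid, would read. Chloro or trifluoromethyl there would show whether the flat reading extends beyond a single fluorine atom.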